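The compounds below may be only part of what the source reports. "The series", "measured", "known", "first", "only" and "open" are said of these compounds alone.

Notes on the series. Compound 1 `Cc1c(-c2ccccc2)sc(N)c1C(=O)c1ccc(Cl)cc1` and compound 2 `CC(C)(C)Cc1c(-c2cc(F)ccc2F)sc(N)c1C(=O)c1ccc(Cl)cc1` share one core and have both been run in an assay on CHO cells for displacement of a labelled ligand from adenosine receptor A1 (Homo sapiens), read by scintillation counting, tested at 10 uM; a lower number here means less inhibition, a higher number more inhibition at the concentration tested (going by the name of the read-out). In this assay compound 1 gives 1%. In this assay compound 2 gives 3%. Among the measured compounds shown here, the two readings lie within the scatter of each other, so compound 2 stands on a par with compound 1, both at the low end of the read-out, and no step between them can be drawn. Compound 3 `CC(C)(C)Cc1c(-c2cn[nH]c2)sc(N)c1C(=O)c1ccc(Cl)cc1` has not yet been run in this assay. It differs from compound 2 in one place: 1H-pyrazol-4-yl in place of 2,5-difluorophenyl on an aromatic carbon. For the measured compounds named here, no measured step covers such a change, so the only footing is that both measured compounds sit near the floor of the read-out. The expected step is no change at the digits printed from compound 2 to compound 3 (within the scatter), with no direction beyond the scatter. Compound 3 is expected to give 3% in this assay, within a range from 0% to 12%.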

Compound 3, a percentage reported as inhibition, at one concentration (the size of the read-out at that concentration, not a potency): 1%
The estimate for compound 3 lay 2 percentage points above the measured number, and the stated range covers the measured number.
By their numbers in this assay, from the lowest: compounds 1, 3 and 2 (each within the scatter of the next).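

With the neopentyl group kept, 1H-pyrazol-4-yl in place of 2,5-difluorophenyl on the aromatic carbon next to the ring sulfur gives a number 2 percentage points lower from compound 2 to compound 3 (within the scatter) in this assay. This position therefore takes a five-membered aromatic ring with 2 hetero atoms, 1 hydrogen-bond donor and 1 hydrogen-bond acceptor, as well as a six-membered ring of carbon only, and in both cases the reading stays at the low end of the read-out. Nothing at hand gives a reason for these readings.

Still open, on these data alone, is whether any group on this carbon lifts the reading off the low end, for instance a carboxylic acid or an aminomethyl group in place of the aromatic ring. Compounds 1 and 2 differ in more than one place, so the part played by the neopentyl group on its own also stays unread.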